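The source may report more compounds than this note shows. Statements on the series, on what has been measured and on what is new or still open speak of the compounds shown alone.

In a functional assay on PC-3 cells (Homo sapiens) for inhibition (a lower number here means a stronger inhibitor, a higher number a weaker inhibitor), compound 3 `Cc1ccc(O)c(/C=N\NC(=O)c2oc3cccc(O)c3c2C)c1` gives 7350 nM, the lowest of the three numbers recorded so far. Compound 1 `Cc1c(C(=O)N/N=C\c2ccc(O)cc2)oc2cccc(O)c12` gives 21700 nM, and compound 2 `Cc1c(C(=O)N/N=C\c2cccc(F)c2O)oc2cccc(O)c12` gives 12700 nM. The step of a 3.0-fold lower number from compound 1 to compound 3 (0.47 log units; beyond the scatter) is modest but beyond the scatter, whereas a 1.7-fold lower number from compound 2 to compound 3 (0.24 log units; within the scatter) and a 1.7-fold lower number from compound 1 to compound 2 (0.23 log units; within the scatter) both stay within it. Compound 4 `Cc1c(C(=O)N/N=C\c2ccccn2)oc2cccc(O)c12` differs from compound 3 by pyridin-2-yl in place of 2-hydroxy-5-methylphenyl on a carbon with a double bond to nitrogen. Going by the values given here, none of the measured steps exchanges the carbon-only ring for one with a hetero atom or removes the hydrogen-bond donor, so the measured steps show only that changes at this position have moved the number modestly. A step of a 2.2-fold higher number from compound 3 to compound 4 (0.34 log units; beyond the scatter) toward a higher number is expected. Compound 4 is therefore estimated at 16000 nM, with a range from 5000 nM to 50000 nM.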

Compound 4, half-maximal inhibitory concentration: >= 40000 nM
Compound 4: a limit, no number; the forecaster's own chance of this, stated with the estimate: 10%; middle value at least 2.5-fold (0.39 log units) from the limit.
By their numbers in this assay, from the lowest: compounds 3, 2 and 1 (each within the scatter of the next, the first and the last beyond it). At a limit, above all of these: compound 4.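

In this assay compound 4 is held at a limit, not a number: the limit of >= 40000 nM in this assay, at which 1 of the 4 values shown sits. Pyridin-2-yl is the first group here to replace the hydroxyl-bearing carbon-only ring, giving an at least 5.4-fold higher number from compound 3 to compound 4 (0.73 log units; beyond the scatter) and an at least 3.1-fold higher number from compound 2 to compound 4 (0.49 log units; beyond the scatter), while an at least 1.8-fold higher number from compound 1 to compound 4 (0.26 log units; that floor lies within the scatter) has a floor that cannot separate the pair. This position therefore tolerates exchange among hydroxyphenyl groups better than this single change, at least against the two lower compounds.

Going by these compounds, whether the ring nitrogen or the lost hydroxyl drives the rise stays open, as both change together. A plain phenyl group on this carbon would separate them.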